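A few compounds are considered here, and "the series" means these few. Any claim that something is new, unique, unknown or untested is made for them only; others in the source may bear on it.

Working notes on the series in a functional assay on SK-OV-3 cells (Homo sapiens) for antiproliferative activity, read by MTT assay, with a stated time of 72 h; a higher number here means a weaker inhibitor, a lower number a stronger inhibitor. Compound 1 `O=C(CCc1cccc2c1B(O)OC2)Nc1ccc(F)cc1` gives 720 nM, compound 3 `Cc1ccc(NC(=O)CCc2cccc3c2B(O)OC3)cc1` gives 860 nM, and compound 2 `O=C(CCc1cccc2c1B(O)OC2)Nc1ccc(I)cc1` gives 51000 nM. Compound 3 therefore sits level with compound 1, as shown by a 1.2-fold higher number from compound 1 to compound 3 (0.08 log units; within the scatter), and far from compound 2, as shown by a 59-fold lower number from compound 2 to compound 3 (1.77 log units; beyond the scatter).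

Compound 4 `COc1ccc(NC(=O)CCc2cccc3c2B(O)OC3)cc1` is still to be measured and carries one change from compound 3: methoxy in place of methyl on an aromatic carbon. This is methoxy in place of methyl on an aromatic carbon, para to a large group.

Two measured steps at the same place bear on it. Methyl in place of fluoro stayed within the scatter, whereas iodo in place of fluoro gave a large step, a 71-fold higher number from compound 1 to compound 2 (1.85 log units; beyond the scatter). Among the measured compounds shown here, no measured compound carries methoxy, so neither step settles the outcome, and the range must stay wide. For the measured compounds named here, compound 2 is the only outlier among three compounds, so a modest upward move in this assay is expected rather than a large one. The estimated step is a 1.4-fold higher number from compound 3 to compound 4 (0.14 log units; within the scatter). For compound 4 the estimated value is 1200 nM, with an expected range of 350 nM to 5000 nM.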

Compound 4, half-maximal inhibitory concentration: 900 nM
Beside the measured number, compound 4's estimate is 1.3-fold (0.12 log units) above it; low and high end bracket the measured number.
By their numbers in this assay, from the lowest: compounds 1, 3 and 4 (each within the scatter of the next); then compound 2.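

In this assay, methoxy in place of methyl on an aromatic carbon, para to a large group, brings in a hydrogen-bond acceptor without moving the number beyond the scatter (a 1.0-fold higher number from compound 3 to compound 4 (0.02 log units; within the scatter)), and the comparison with fluoro also stays within it (a 1.3-fold higher number from compound 1 to compound 4 (0.10 log units; within the scatter)). Fluoro, methyl and methoxy therefore sit level at this position, while compound 2, with iodo, remains the one compound apart (a 57-fold lower number from compound 2 to compound 4 (1.75 log units; beyond the scatter)). Nothing at hand accounts for either the level values or the iodo outlier.

Open, from the compounds shown here alone, is how chloro and bromo behave at this place, and with them where between fluoro and iodo the large step sets in. Also open, going by these compounds, is whether an amine or a carboxylic acid here would stay level with compound 1.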